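From fluoro to bromo on compound 3

The compounds below may be only part of what the source reports. "The series", "measured", "known", "first", "only" and "open" are said of these compounds alone.

Compound 1 `Fc1ccccc1-c1ccc2[nH]c(C3=NOC4(CCCCC4)C3)nc2c1`: 79%
Compound 2 `FC(F)(F)Oc1ccccc1-c1ccc2[nH]c(C3=NOC4(CCCCC4)C3)nc2c1`: 100%
Compound 3 `Fc1cc(-c2ccccc2C(F)(F)F)cc2nc(C3=NOC4(CCCCC4)C3)[nH]c12`: 46%

In an ADME assay on microsomes from liver (Homo sapiens) for metabolic stability, with a stated time of 10 min (a lower number here means that less of the compound is left, a higher number that more of the compound is left), compound 3 stands lowest of the three at 46%, while compound 1 gives 79% and compound 2 gives 100%. The gaps from compound 3 to each of these two compounds lie beyond the scatter.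

Compound 4 `FC(F)(F)c1ccccc1-c1cc(Br)c2[nH]c(C3=NOC4(CCCCC4)C3)nc2c1` differs from compound 3 at one place: bromo in place of fluoro on an aromatic carbon. The swap is bromo in place of fluoro on an aromatic carbon, ortho to a fused ring.

For the measured compounds named here, only one measured step is available as a guide: a number 21 percentage points higher from compound 1 to compound 2 (beyond the scatter), with trifluoromethoxy in place of fluoro on an aromatic carbon. That modest step also replaces a fluoro, but at a different place and with a different group, so it bears only loosely on this swap. Going by the values given here, no measured step shows bromo in place of fluoro. A step beyond the scatter is therefore not expected, although a slight rise in the number is tentatively favoured. The estimated step is a number 4 percentage points higher from compound 3 to compound 4 (within the scatter). Compound 4 is expected at 50%, with an estimated range of 28% to 74%.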

Compound 4, percent of the compound remaining: 100%
For compound 4 the middle estimate is 50 percentage points below the measured one; the whole stated range lies below it.
By their numbers in this assay, from the lowest: compound 3; then compound 1; then compounds 2 and 4 (each within the scatter of the next).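

In this assay this position proves highly sensitive to the choice of halogen, with a number 54 percentage points higher from compound 3 to compound 4 (beyond the scatter) when bromo replaces fluoro on the aromatic carbon ortho to a fused ring and meta to a 2-(trifluoromethyl)phenyl group. For the compounds shown here, the only earlier step, a number 21 percentage points higher from compound 1 to compound 2 (beyond the scatter), lies at another place, so it gave no view of this one. Here, one heavy atom replaces another, with no ring, hydrogen-bond donor, hydrogen-bond acceptor or net charge entering or leaving, yet the change is large, and nothing measured accounts for it.

The compounds shown leave open whether this rise is particular to bromo or would also appear with chloro, methyl or methoxy at the same carbon. They also leave open whether bromo would act alike with a 2-(trifluoromethoxy)phenyl group in place of the 2-(trifluoromethyl)phenyl group.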